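This account rests on a few compounds, and the source may have more. Where it says the series, first, only, none or still open, it means among the compounds named here.

Measured in a functional assay on U-251 cells (Homo sapiens); on this read-out higher numbers stand for weaker inhibition of growth and lower numbers for stronger inhibition of growth
compound 1 `O=S(=O)(/C=C/c1ccc(F)cc1Cl)Cc1ccc(Nc2ncnc3ccccc23)cc1` gives 100000 nM
compound 2 `O=S(=O)(/C=C/c1ccc(C(F)(F)F)cc1F)Cc1ccc(Nc2ncnc3ccccc23)cc1` gives 100000 nM

Compound 1 stands level with compound 2 at the digits shown. Among the compounds with values here, the only measured step, no change at the digits printed from compound 1 to compound 2 (within the scatter), lies at a different place, so it bears on the new change only indirectly. Within the data shown here, compound 3 `O=S(=O)(/C=C/c1ccc(F)cc1Cl)Cc1ccc(Nc2ncnc3cc(Cl)ccc23)cc1` differs from compound 1 by chloro in place of hydrogen on an aromatic carbon, and no measured step covers that change. No shift beyond the scatter is expected in this assay, though stronger inhibition cannot be excluded. The expected step is a 1.4-fold lower number from compound 1 to compound 3 (0.15 log units; within the scatter). The estimated value for compound 3 is 70000 nM, with an expected range of 15000 nM to 120000 nM.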

Compound 3, concentration for 50% growth inhibition: 2000 nM
The estimate for compound 3 lay 35-fold (1.54 log units) above the measured number, and the stated range ends above it.
By their numbers in this assay, from the lowest: compound 3; then compounds 1 and 2 (each within the scatter of the next).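

In this assay chloro in place of hydrogen on an aromatic carbon of the fused two-ring system gives a 50-fold lower number from compound 1 to compound 3 (1.70 log units; beyond the scatter) and so marks this position as one where a single chlorine atom moves the number well beyond the scatter. The earlier pair, compound 1 and compound 2, differed elsewhere and said nothing about this position. No measured data here account for the size of this step.

Open, going by these compounds, is whether fluoro, methoxy or an amine at the same carbon would give a similar step. Also open, on these data alone, is whether chloro here would give the same step on compound 2.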